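From Compound 1 to Compound 4: Expected Cytotoxicity

The source may hold more compounds than are shown below. What is called first, only, known or untested is meant among the compounds shown, and "the series" means these compounds.

Compound 1, `Cc1ccsc1C(=O)N1CCCn2nc(C(=O)Nc3ccccc3)cc2C1`: "not determined" (no result reported)
Compound 2, `Cc1c(C(=O)N2CCCn3nc(C(=O)Nc4ccccc4)cc3C2)oc2ccccc12`: "not determined" (no result reported)
Compound 3, `O=C(Nc1ccccc1)c1cc2n(n1)CCCN(C(=O)c1occc1C(F)(F)F)C2`: 30000 nM

In an ADME assay on BEAS-2B cells (Homo sapiens) for cytotoxicity, read by fluorescence, with a stated time of 48 h (on this read-out lower numbers stand for higher toxicity in this test and higher numbers for lower toxicity in this test), compound 1 gives "not determined" (no result reported), so it stands nowhere on the numbers: there is no value to rank it by. Compound 2 likewise gives "not determined" (no result reported). Going by the values given here, the one number in this assay comes from compound 3, which gives 30000 nM. Compound 4, `Cc1coc(C(=O)N2CCCn3nc(C(=O)Nc4ccccc4)cc3C2)c1C`, is still to be measured. It differs from compound 1 in one place: 3,4-dimethylfuran-2-yl in place of 3-methylthiophen-2-yl on a carbonyl carbon. Among the compounds with values here, with no value for compound 1, the step cannot be sized; what can be said is that the three compounds share one core, and the only measured member, compound 3, shows low toxicity. For compound 4 a value in that same region is expected, with no step beyond the scatter from compound 3, because compound 3 gives 30000 nM and nothing points another way. The estimate for compound 4 in this assay is 30000 nM, expected to fall between 10000 nM and 100000 nM.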

Compound 4, half-maximal cytotoxic concentration: 30000 nM
Compound 4: the middle estimate sits on the measured number at the digits printed, within the range that was stated.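

In this assay, 3,4-dimethylfuran-2-yl in place of 3-(trifluoromethyl)furan-2-yl on the carbonyl carbon gives no change at the digits printed from compound 3 to compound 4 (within the scatter). Going by these compounds alone, this is the first comparison at this position, which until now had a single number: these two furan groups read alike, although one carries two methyl groups and the other a trifluoromethyl group. Nothing available explains this match. The step from compound 1 to compound 4 cannot be read. Going by these compounds, whether a furan carrying an amine or a carboxylic acid would read the same remains open.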